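Moving the halogen from the second to the fourth position

A few compounds are considered here, and "the series" means these few. Any claim that something is new, unique, unknown or untested is made for them only; others in the source may bear on it.

In a functional assay on SK-BR-3 cells (Homo sapiens) for antiproliferative activity, read by MTT assay, with a stated time of 72 h (on this read-out higher numbers stand for weaker inhibition and lower numbers for stronger inhibition), compound 1 `CCN1CCN(c2cc(C)c3cc(NC(=O)c4ccc(Cl)cc4)ccc3n2)CC1` gives 3020 nM. Compound 2 `CCN1CCN(c2cc(C)c3cc(NC(=O)c4ccccc4OC)ccc3n2)CC1`, which carries a 2-methoxyphenyl on the carbonyl carbon, gives 15700 nM in this assay, and a 5.2-fold higher number from compound 1 to compound 2 (0.72 log units; beyond the scatter). For compound 3 `CCN1CCN(c2cc(C)c3cc(NC(=O)c4ccccc4Cl)ccc3n2)CC1` this assay reports only a limit, > 50000 nM (the limit of > 50000 nM in this assay, at which 1 of the 3 values shown sits), so no exact number is known for it. With an at least 3.1-fold higher number from compound 2 to compound 3 (0.50 log units; beyond the scatter), compound 3 stands as the weakest of the three measured compounds.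

Compound 4 `CCN1CCN(c2cc(C)c3cc(NC(=O)c4ccc(Br)cc4)ccc3n2)CC1` differs from compound 3 by 4-bromophenyl in place of 2-chlorophenyl on a carbonyl carbon. The step that bears on this change is the one between the 4-chlorophenyl and 2-chlorophenyl compounds: an at least 16-fold higher number from compound 1 to compound 3 (1.21 log units; beyond the scatter). Compound 4 carries a 4-bromophenyl where compound 1 carries a 4-chlorophenyl, so this change is expected to largely undo that step, giving an estimated at least 14-fold lower number from compound 3 to compound 4 (1.15 log units; beyond the scatter). Close to where compound 1 sits, compound 4 is therefore expected at 3500 nM, with a likely range from 1200 nM to 12000 nM.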

Compound 4, half-maximal inhibitory concentration: 6310 nM
Compound 4: middle estimate off by 1.8-fold (0.26 log units), on the low side, and the stated range covers the measured number.
By their numbers in this assay, from the lowest: compound 1; then compound 4; then compound 2. At a limit, above all of these: compound 3.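

In this assay, among the compounds shown here, the 4-chlorophenyl of compound 1 is no longer the only group that restores activity: with 4-bromophenyl on the carbonyl carbon the number falls again, an at least 7.9-fold lower number from compound 3 to compound 4 (0.89 log units; beyond the scatter). The two halogens are still not interchangeable here, with a 2.1-fold higher number from compound 1 to compound 4 (0.32 log units; beyond the scatter), although compound 4 keeps an edge over the methoxy compound, a 2.5-fold lower number from compound 2 to compound 4 (0.40 log units; beyond the scatter). The first of these steps has no upper end, since compound 3 stands at a limit of the assay: the limit of > 50000 nM in this assay, at which 1 of the 4 values shown sits.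

On these data alone, whether a 2-bromophenyl would fall as far as compound 3 remains open. So does how a 4-methoxyphenyl, the direct partner of compound 2, or a 4-aminophenyl would read, which would show whether this preference reaches beyond halogens.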